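Swapping trifluoromethyl for bromo on a shared core

This account rests on a few compounds, and the source may have more. Where it says the series, first, only, none or still open, it means among the compounds named here.

Compound 2 `CC(c1ccc(-c2ccccc2)c(F)c1)c1nnc2n1N=C(c1ccc(C(F)(F)F)cc1)CS2` gives 9400 nM in a functional assay on Huh-7 cells (Homo sapiens) for inhibition, read by sulforhodamine B assay, with a stated time of 72 h; a lower number here means a stronger inhibitor, a higher number a weaker inhibitor. Compound 1 `CC(c1ccc(-c2ccccc2)c(F)c1)c1nnc2n1N=C(c1ccccc1)CS2` gives 6700 nM, and compound 3 `COc1ccc2cc(C(C)c3nnc4n3N=C(c3ccc(Cl)cc3)CS4)ccc2c1` gives 5600 nM, so all three numbers lie within the usual scatter of one another. Within the data shown here, the step of a 1.4-fold higher number from compound 1 to compound 2 (0.15 log units; within the scatter) is the only measured step that touches the same position, and it stays within the scatter. Compound 4 `CC(c1ccc(-c2ccccc2)c(F)c1)c1nnc2n1N=C(c1ccc(Br)cc1)CS2` differs from compound 2 by bromo in place of trifluoromethyl on an aromatic carbon. Because that measured step a 1.4-fold higher number from compound 1 to compound 2 (0.15 log units; within the scatter) was small, no step beyond the scatter is expected for compound 4 in this assay, and the expected step of a 1.3-fold lower number from compound 2 to compound 4 (0.10 log units; within the scatter) leans only slightly toward a lower number. Compound 4 is therefore estimated at 7500 nM, within 3000 nM to 20000 nM.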

Compound 4, half-maximal inhibitory concentration: 5000 nM
Compound 4: the middle estimate sits 1.5-fold (0.18 log units) above what was measured, within the range that was stated.
By their numbers in this assay, from the lowest: compounds 4, 3, 1 and 2 (each within the scatter of the next).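

Bromo now joins hydrogen and trifluoromethyl at this place on the ring, and neither a 1.9-fold lower number from compound 2 to compound 4 (0.27 log units; within the scatter) nor a 1.3-fold lower number from compound 1 to compound 4 (0.13 log units; within the scatter) leaves the scatter. With the rest of the shared core unchanged, these three groups give numbers that cannot be told apart in this assay. No evidence is available on why the number responds so little to this change. On these data alone, whether an amine or a carboxylic acid here would give a step beyond the scatter stays open. So does whether a bromo or a hydrogen would behave the same on the core of compound 3.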